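From Neopentylcarbonyl to Acetyl on a Receptor Modulator

This account rests on a few compounds, and the source may have more. Where it says the series, first, only, none or still open, it means among the compounds named here.

Compound 1 `COc1cc(C(=O)O)ccc1OCCCCOc1ccc(C(=O)CC(C)(C)C)c(O)c1C` was examined in an assay on HEK293 cells for positive allosteric modulation of metabotropic glutamate receptor 2 (Rattus norvegicus), read by thallium flux, with a stated time of 2.5 min (a higher number here means a larger maximal response, a lower number a smaller maximal response), where compound 1 gives 98.6%. Among the three compounds with numbers, that is the highest: compound 2 `Cc1c(OCCCCOc2ccc(C(=O)O)c(Cl)c2)ccc(C(=O)CC2CCCC2)c1C`, which in this assay gives 61.8%, lies below it by a margin beyond the scatter, and compound 3 `COC(=O)c1ccc(OCCCCOc2ccc(C(=O)CC(C)C)c(O)c2C)cc1`, which in this assay gives 16.4%, lies furthest below. Within the data shown here, neither compound 2 nor compound 3 differs from compound 1 in a single place, so their values stand on their own and no step between any two measured compounds is charted.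

Compound 4 `COc1cc(C(=O)O)ccc1OCCCCOc1ccc(C(C)=O)c(O)c1C` has not yet been measured. It differs from compound 1 in one place: hydrogen in place of tert-butyl on a saturated chain carbon bound to a carbonyl carbon. The neopentylcarbonyl group of compound 1 thus becomes an acetyl group. Among the measured compounds shown here, with no measured pair to lean on, the account can only note that compound 2 and compound 3, which carry other groups in the corresponding place, both show lower values than compound 1, though each also differs from compound 1 elsewhere. Compound 4 is therefore expected to show a drop in this assay, with the step of a number 53.6 percentage points lower from compound 1 to compound 4 (beyond the scatter) estimated as a decrease beyond the scatter. The estimate for compound 4 in this assay is 45%, within a range from 10% to 85%.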

Compound 4, largest response reached (reported as percent of maximum), in percent of the reference or control that the assay uses: 86.3%
Compound 4: middle estimate off by 41.3 percentage points, on the low side, and the stated range ends below it.
By their numbers in this assay, from the lowest: compound 3; then compound 2; then compound 4; then compound 1.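

In this assay, among these compounds, the step of a number 12.3 percentage points lower from compound 1 to compound 4 (beyond the scatter) gives the first direct reading of this position, the saturated chain carbon bound to a carbonyl carbon, and it is modest although beyond the scatter. Removing the tert-butyl group, with all of its carbon atoms, and leaving only hydrogen in its place turns neopentylcarbonyl into acetyl, yet compound 4 still gives 86.3%, so a large maximal response in this series does not depend on the tert-butyl group. The data offer no measurement that accounts for the size of this step.

As far as these compounds go, with only the two ends of this change in a matched pair, it remains open how the response behaves with a group of intermediate size in that place, such as an ethyl group, or with a longer chain, an amine or a carboxylic acid there. Also unsettled is whether the same change from neopentylcarbonyl to acetyl would produce a step of similar size on a core other than that of compound 1.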